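What an added ethyl may do

A few compounds are considered here, and "the series" means these few. Any claim that something is new, unique, unknown or untested is made for them only; others in the source may bear on it.

Of the compounds shown here, three with a shared core have been measured in a functional assay on the whole organism with Rattus norvegicus as the target; a higher number here means that more compound is needed for the effect, a lower number that less compound is needed. Compound 1 `CCOC(=O)c1c(C[S+]([O-])c2nccn2C)nc2cc(OC)c(OC)cc2c1-c1ccc(OC)c(OC)c1` gives 6.5 mg/kg, compound 2 `CCOC(=O)c1c(CCc2nccn2C)nc2cc(OC)c(OC)cc2c1-c1ccc(OC)c(OC)c1` gives 14.7 mg/kg, and compound 3 `CCOC(=O)c1c(Cn2ccnc2)nc2cc(OC)c(OC)cc2c1-c1ccc(OC)c(OC)c1` gives 7.7 mg/kg. Going by the values given here, the only step beyond the scatter is a 2.3-fold higher number from compound 1 to compound 2 (0.35 log units; beyond the scatter). The other two stay within it: a 1.2-fold higher number from compound 1 to compound 3 (0.07 log units; within the scatter) and a 1.9-fold lower number from compound 2 to compound 3 (0.28 log units; within the scatter). Compound 3 therefore cannot be told apart from either of the others.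

Compound 4 `CCOC(=O)c1c(Cn2ccnc2CC)nc2cc(OC)c(OC)cc2c1-c1ccc(OC)c(OC)c1` turns 1H-imidazol-1-yl into 2-ethyl-1H-imidazol-1-yl: ethyl in place of hydrogen on an aromatic carbon. The ethyl sits on an aromatic carbon between two ring nitrogen atoms. Among the compounds with values here, no measured pair makes this exact change. The closest evidence comes from swapping the whole group on the saturated chain carbon, and even the largest such swap gave only a modest change, a 2.3-fold higher number from compound 1 to compound 2 (0.35 log units; beyond the scatter). These steps show no direction for an added ethyl, so no change beyond the scatter is expected in this assay, and the expected step is a 1.0-fold higher number from compound 3 to compound 4 (0.02 log units; within the scatter). Compound 4 is estimated at 8 mg/kg, with an expected range from 3.5 mg/kg to 18 mg/kg.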

Compound 4, dose for half-maximal effect: 9.1 mg/kg
The estimate for compound 4 lay 1.1-fold (0.06 log units) below the measured number, and the stated range covers the measured number.
By their numbers in this assay, from the lowest: compounds 1, 3, 4 and 2 (each within the scatter of the next, the first and the last beyond it).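

Going by these compounds alone, with ethyl in place of hydrogen on an aromatic carbon, between two ring nitrogen atoms and next to the ring atom that bears a large group, this assay gives a 1.2-fold higher number from compound 3 to compound 4 (0.07 log units; within the scatter), the first direct reading of a change at this position, and it shows that this ethyl leaves the number within the scatter. Compound 4 also stays within the scatter of both other compounds, with a 1.6-fold lower number from compound 2 to compound 4 (0.21 log units; within the scatter) and a 1.4-fold higher number from compound 1 to compound 4 (0.15 log units; within the scatter), even though those two compounds lie beyond the scatter of each other. Nothing available gives a reason for this result.

On these data alone, a single ethyl gives only one point at this position, so it remains open whether methyl, a longer chain, an amine or a carboxylic acid on the same aromatic carbon would also stay within the scatter. As far as these compounds go, whether such a group would behave the same way on the other side chains of compound 1 and compound 2 also remains open.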